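The source may hold more compounds than are shown below. What is called first, only, known or untested is meant among the compounds shown, and "the series" means these compounds.

In a functional assay on PC-3 cells (Homo sapiens) for antiproliferative activity, read by MTT assay, with a stated time of 48 h (a higher number here means a weaker inhibitor, a lower number a stronger inhibitor), compound 3 `COc1ccc(CN(C(=O)Cn2cc(CSC3=NCCS3)nn2)c2cc(OC)c(OC)c(OC)c2)cc1` gives 16000 nM. That value lies within the scatter of compound 2 `COc1ccc(CN(C(=O)Cn2cc(CSc3nc4ccccc4s3)nn2)c2cc(OC)c(OC)c(OC)c2)cc1` at 28500 nM, while compound 1 `COc1ccc(CN(C(=O)Cn2cc(COc3ccc4c(C)cc(=O)oc4c3)nn2)c2cc(OC)c(OC)c(OC)c2)cc1`, at 340 nM, stands well beyond the scatter on the stronger side. Compound 4 `COc1ccc(CN(C(=O)Cn2cc(CSc3nnnn3C)nn2)c2cc(OC)c(OC)c(OC)c2)cc1` keeps the shared core and changes only the group on the sulfur: a group of 6 heavy atoms (2 carbon, 4 nitrogen; one five-membered aromatic ring with 4 hetero atoms) in place of a group of 5 heavy atoms (3 carbon, 1 nitrogen, 1 sulfur; one five-membered non-aromatic ring with 2 hetero atoms), on a sulfur. Among the compounds with values here, the one measured step of this kind is a 1.8-fold lower number from compound 2 to compound 3 (0.25 log units; within the scatter), where replacing the group on the sulfur moved the number no further than the scatter. A similar swap is therefore expected to give no step beyond the scatter in this assay. The expected step is a 1.1-fold lower number from compound 3 to compound 4 (0.03 log units; within the scatter). For compound 4 the estimated value is 15000 nM, with an expected range from 5000 nM to 45000 nM.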

Compound 4, half-maximal inhibitory concentration: 10900 nM
Compound 4: middle estimate off by 1.4-fold (0.14 log units), on the high side; the measured number falls inside the stated range.
By their numbers in this assay, from the lowest: compound 1; then compounds 4, 3 and 2 (each within the scatter of the next, the first and the last beyond it).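

In this assay, the step of a 1.5-fold lower number from compound 3 to compound 4 (0.17 log units; within the scatter) stays within the scatter, so 1-methyl-1H-tetrazol-5-yl and the five-membered non-aromatic ring it replaces give matching numbers on this sulfur. The step of a 2.6-fold lower number from compound 2 to compound 4 (0.42 log units; beyond the scatter) passes the scatter and is the only one on this sulfur to do so, though it remains modest. Nothing given here explains either step. From the compounds shown here alone, whether a plain methyl or a chain ending in an amine on this sulfur would shift the number further remains open.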